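Changing the aryl group on the piperazine sulfonamide

This account rests on a few compounds, and the source may have more. Where it says the series, first, only, none or still open, it means among the compounds named here.

Compounds measured so far:
- compound 1, `CCCn1c(=O)[nH]c2nc(-c3ccc(S(=O)(=O)N(C)C)cc3)[nH]c2c1=O`: 1220 nM
- compound 2, `CCCn1c(=O)[nH]c2nc(-c3ccc(S(=O)(=O)N4CCN(c5ccccc5C)CC4)cc3)[nH]c2c1=O`: > 1000 nM
- compound 3, `CCCn1c(=O)[nH]c2nc(-c3ccc(S(=O)(=O)N4CCN(c5cccc(Cl)c5)CC4)cc3)[nH]c2c1=O`: 53.5 nM

Of the compounds shown here, three sharing one core have been tested in an assay on CHO cells for displacement of a labelled ligand from adenosine receptor A3 (Homo sapiens), read by scintillation counting, with a stated time of 45 min, in the presence of a further agent that is not named here; on this read-out lower numbers stand for stronger inhibition and higher numbers for weaker inhibition. Compound 1 gives 1220 nM. Compound 2 reaches only the limit of the assay, reported as > 1000 nM, so no number is known for it. Compound 3 gives 53.5 nM, the lowest of the two numbers available; compound 1, its nearest neighbour, lies well above it, beyond the scatter. Among the measured compounds shown here, the one measured step on the aryl group attached to the ring nitrogen is an at least 18-fold lower number from compound 2 to compound 3 (1.27 log units; beyond the scatter), and it is bounded only by the limit of > 1000 nM in this assay, at which 1 of the 3 values shown sits.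

Compound 4, `CCCn1c(=O)[nH]c2nc(-c3ccc(S(=O)(=O)N4CCN(c5ccc(C)cc5)CC4)cc3)[nH]c2c1=O`, is not yet measured. It differs from compound 3 by 4-methylphenyl in place of 3-chlorophenyl on an amine nitrogen in a ring. For the measured compounds named here, the only step that bears on this change is the large one from compound 2 to compound 3, which shows that the identity of this aryl group can move the number a great deal. The new change is a different exchange on the same nitrogen, so its size cannot be read directly from that step. A moderate rise in the number is expected, a 2.8-fold higher number from compound 3 to compound 4 (0.45 log units; beyond the scatter). For compound 4 the expected value in this assay is 150 nM, within a range of 30 nM to 1000 nM.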

Compound 4, inhibition constant: > 1000 nM
Compound 4 was reported as a limit (the forecaster's own chance of this, stated with the estimate: 15%); at least 6.6-fold (0.82 log units) between middle value and limit.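

On the amine nitrogen in the ring, putting 4-methylphenyl in place of 3-chlorophenyl gives an at least 18-fold higher number from compound 3 to compound 4 (1.27 log units; beyond the scatter) in this assay, so a change of this aryl group alone can again move the number a great deal. Among the compounds shown here, until now, the only aryl group with a limit was 2-methylphenyl, which left open that this one group was a special case, but compound 4 also stops at a limit of the assay, so the loss is not confined to 2-methylphenyl. The two methylphenyl compounds cannot be ranked against each other, because compound 2 and compound 4 both stop at the same limit: the limit of > 1000 nM in this assay, at which 2 of the 4 values shown sit.

Of the three aryl groups shown on this nitrogen, only 3-chlorophenyl gives a number, but it differs from 4-methylphenyl in both the substituent and its place on the ring, so the compounds shown cannot say which of the two matters. 3-Methylphenyl and 4-chlorophenyl would each change only one of these at a time, and it remains open whether either would give a number or would also stop at the limit.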